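A few compounds are considered here, and "the series" means these few. Any claim that something is new, unique, unknown or untested is made for them only; others in the source may bear on it.

Series notes. In a functional assay on MCF7 cells (Homo sapiens) for inhibition, read by sulforhodamine B assay, with a stated time of 72 h (a higher number here means a weaker inhibitor, a lower number a stronger inhibitor), compound 1 `COc1ccc2cc(C(C)c3nnc4n3N=C(c3ccc([N+](=O)[O-])cc3)CS4)ccc2c1` gives 18800 nM, compound 2 `COc1ccc2cc(C(C)c3nnc4n3N=C(c3ccc(Cl)cc3Cl)CS4)ccc2c1` gives 14600 nM and compound 3 `COc1ccc(C2=Nn3c(nnc3C(C)c3ccc4cc(OC)ccc4c3)SC2)cc1` gives 6600 nM, the lowest of the three numbers. The step of a 2.8-fold lower number from compound 1 to compound 3 (0.45 log units; beyond the scatter) and the step of a 2.2-fold lower number from compound 2 to compound 3 (0.34 log units; beyond the scatter) both lie beyond the scatter, while a 1.3-fold lower number from compound 1 to compound 2 (0.11 log units; within the scatter) does not. Compound 4 `COc1ccc2cc(C(C)c3nnc4n3N=C(c3ccc(C)cc3)CS4)ccc2c1` differs from compound 3 by methyl in place of methoxy on an aromatic carbon. Among the measured compounds shown here, none of the measured steps exchanges methoxy for methyl; the two steps that arrive at compound 3 show that replacing the group on that aromatic carbon shifted this assay only modestly. For compound 4 a small change is therefore expected in this assay, a 1.4-fold higher number from compound 3 to compound 4 (0.16 log units; within the scatter), staying close to compound 3. Compound 4 is estimated at 9500 nM, range 4500 nM to 20000 nM.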

Compound 4, half-maximal inhibitory concentration: 11000 nM
Beside the measured number, compound 4's estimate is 1.2-fold (0.06 log units) below it, within the range that was stated.
By their numbers in this assay, from the lowest: compounds 3, 4, 2 and 1 (each within the scatter of the next, the first and the last beyond it).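

In this assay methyl in place of methoxy on the aromatic carbon para to a large group gives a 1.7-fold higher number from compound 3 to compound 4 (0.22 log units; within the scatter) and so stays within the scatter, even though the one hydrogen-bond acceptor of methoxy leaves. The 4-methylphenyl is not resolved from the other two groups either: a 1.3-fold lower number from compound 2 to compound 4 (0.12 log units; within the scatter) and a 1.7-fold lower number from compound 1 to compound 4 (0.23 log units; within the scatter) both stay within the scatter, though compound 1 and compound 3 remain apart. No evidence on the cause of these results is available.

As far as these compounds go, whether an amine, a carboxylic acid or a longer chain such as ethoxy on that aromatic carbon would take the number beyond the scatter of methoxy remains open.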